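Trimming the Ester of a Thiophene-Bearing Core

This account rests on a few compounds, and the source may have more. Where it says the series, first, only, none or still open, it means among the compounds named here.

Compound 1 `CC(C)OC(=O)C1=C(C(F)(F)F)NC(=O)NC1c1ccoc1` is a cyclic urea carrying a trifluoromethyl group, an isopropyl ester and a furan-3-yl ring on a saturated ring carbon. In an assay on HEK293 cells for displacement of a labelled ligand from adenosine receptor A2b (Homo sapiens), read by radioligand binding, with a stated time of 30 min, tested at 1 uM (on this read-out lower numbers stand for less inhibition and higher numbers for more inhibition at the one concentration tested (going by the name of the read-out)), compound 1 gives 37%. Compound 2 `CC(C)OC(=O)C1=C(C(F)(F)F)NC(=O)NC1c1cccs1` keeps everything except that a thiophen-2-yl ring replaces the furan-3-yl ring, and in this assay compound 2 gives 19%. For the measured compounds named here, that swap amounts to a number 18 percentage points lower from compound 1 to compound 2 (beyond the scatter), and it leaves compound 2 with the lowest of the two numbers measured so far.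

Compound 3 `CCOC(=O)C1=C(C(F)(F)F)NC(=O)NC1c1cccs1` keeps the thiophene of compound 2 and alters only the ester. The change is hydrogen in place of methyl on a saturated chain carbon bound to an oxygen next to a carbonyl group and a saturated chain carbon. Going by the values given here, no measured step touches this part of the molecule; the one step measured concerns the ring on the saturated ring carbon, not the ester. With nothing to suggest a shift in either direction, the expectation for this assay is a step of no change at the digits printed from compound 2 to compound 3 (within the scatter), within the usual scatter. Compound 3 is therefore estimated at 19%, with a likely range from 5% to 35%.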

Compound 3, a percentage reported as inhibition, at one concentration (the size of the read-out at that concentration, not a potency): 16%
Compound 3: middle estimate off by 3 percentage points, on the high side; the measured number falls inside the stated range.
By their numbers in this assay, from the lowest: compounds 3 and 2 (each within the scatter of the next); then compound 1.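

For the compounds shown here, with the thiophen-2-yl ring held fixed, ethoxycarbonyl in place of isopropoxycarbonyl gives the first measured step at the ester, and in this assay it reads as a number 3 percentage points lower from compound 2 to compound 3 (within the scatter). On this read-out, compound 2 and compound 3 cannot be told apart, so this position can lose a methyl without a step beyond the scatter, unlike the earlier ring swap, which gave a number 18 percentage points lower from compound 1 to compound 2 (beyond the scatter). Nothing available explains the result at the ester, and these numbers alone give no reason for it.

The compounds shown leave open whether the same holds for a more distant replacement at this position, such as a carboxylic acid, a primary amide or a longer chain like n-butoxycarbonyl. On these data alone, it also remains open whether ethoxycarbonyl and isopropoxycarbonyl would still read alike alongside the furan-3-yl ring of compound 1, and how any of these single-concentration percentages would translate into a potency.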